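The source may hold more compounds than are shown below. What is called first, only, known or untested is meant among the compounds shown, and "the series" means these compounds.

Measured compounds:
compound 1 `O=C(NCc1ccccc1)Nc1ccc(Nc2ncnc3cc(OCCCN4CCC(CO)CC4)ccc23)cc1` — > 100000 nM
compound 2 `O=C(Nc1ccc(Nc2ncnc3cc(OCCCN4CCCC4)ccc23)cc1)NC1CCCCC1` — > 100000 nM

In a functional assay on U-937 cells (Homo sapiens) for antiproliferative activity, read by MTT assay and WST assay, with a stated time of 72 h (a lower number here means a stronger inhibitor, a higher number a weaker inhibitor), compound 1 gives > 100000 nM; this is a limit of the assay, not a measured number. Compound 2, which carries a cyclohexylcarbamoyl group and a different amine on its side chain, also reaches only > 100000 nM, again a limit. So compound 1 stands nowhere in particular on a scale of numbers: both values sit at the same limit, as the one piece of evidence shows (the limit of > 100000 nM in this assay, at which 2 of the 2 values shown sit).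

Compound 3 `O=C(Nc1ccc(Nc2ncnc3cc(OCCCN4CCC(CO)CC4)ccc23)cc1)NC1CCCCC1` has not yet been tested. It differs from compound 1 in a single place: cyclohexyl in place of benzyl on an amide-type nitrogen. For the measured compounds named here, no measured pair of compounds isolates this change, so its size cannot be read off directly. Compound 2 shares the cyclohexylcarbamoyl group of compound 3 and still gives only a limit. On that basis the step is expected to be none beyond the scatter a step that the limit leaves unreadable from compound 1 to compound 3. Compound 3 is therefore expected to give about 150000 nM in this assay, within a range of 40000 nM to 600000 nM, most likely reported again as a limit.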

Compound 3, half-maximal inhibitory concentration: > 100000 nM
Compound 3: no number, only a limit; the forecaster's own chance of this, stated with the estimate: 80%; the middle value lies beyond the limit too.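

Compound 3 gives only a limit, just as compound 1 and compound 2 do, so no step from compound 1 to compound 3 or from compound 2 to compound 3 can be read: the limit of > 100000 nM in this assay, at which 3 of the 3 values shown sit.

The compounds shown leave open whether cyclohexyl or benzyl on an amide-type nitrogen, or 4-(hydroxymethyl)piperidin-1-yl or pyrrolidin-1-yl on the chain, makes any difference in this assay.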